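Dichlorobenzyl triazole in a weakly cytotoxic chromone series

The source may report more compounds than this note shows. Statements on the series, on what has been measured and on what is new or still open speak of the compounds shown alone.

Compound 1 `Cc1ccc(Cn2cc(COc3ccc4c(=O)ccoc4c3)nn2)cc1` gives 10400 nM in a functional assay on SW480 cells (Homo sapiens) for cytotoxicity, read by MTT assay, with a stated time of 48 h; a lower number here means a stronger inhibitor, a higher number a weaker inhibitor. Compound 2 `N#Cc1ccc(Cn2cc(COc3ccc4c(=O)ccoc4c3)nn2)cc1` reaches only a limit of this assay, > 100000 nM. Compound 3 `Cc1ccccc1Cn1cc(COc2ccc3c(=O)ccoc3c2)nn1` likewise stops at a limit, > 100000 nM.

Compound 2 therefore stands at the weak edge of what is shown, and the step that the two limits leave unreadable from compound 2 to compound 3 because of the limit of > 100000 nM in this assay, at which 2 of the 3 values shown sit.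

Compound 4 `O=c1ccoc2cc(OCc3cn(Cc4ccc(Cl)cc4Cl)nn3)ccc12` carries 2,4-dichlorophenyl in place of 4-cyanophenyl on a saturated chain carbon bound to an aromatic nitrogen. Relevant steps are an at least 9.6-fold higher number from compound 1 to compound 2 (0.98 log units; beyond the scatter) and an at least 9.6-fold higher number from compound 1 to compound 3 (0.98 log units; beyond the scatter), both weakening. The 2,4-dichlorophenyl shares its ring pattern with 2-methylphenyl of compound 3 rather than with 4-methylphenyl of compound 1, so no gain beyond the scatter is expected. Compound 4 is estimated at 60000 nM, with a range of 15000 nM to 200000 nM. The expected step is an at least 1.6-fold lower number from compound 2 to compound 4 (0.22 log units; that floor lies within the scatter).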

Compound 4, half-maximal inhibitory concentration: > 100000 nM
Compound 4: no number, only a limit; the forecaster's own chance of this, stated with the estimate: 45%; middle value at least 1.6-fold (0.22 log units) from the limit.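

Compound 4 gives only a limit, > 100000 nM. Among the compounds shown here, with 2,4-dichlorophenyl in place of 4-methylphenyl there is an at least 9.6-fold higher number from compound 1 to compound 4 (0.98 log units; beyond the scatter), so compound 1 remains the only compound here with a readable number. The steps from compound 2 and from compound 3 to compound 4 cannot be read, because all three stop at the same limit: the limit of > 100000 nM in this assay, at which 3 of the 4 values shown sit.

Any ranking among compound 2, compound 3 and compound 4 stays open. Also open, from the compounds shown here alone, is whether a benzylamine or a benzoic acid on the saturated chain carbon bound to an aromatic nitrogen would give a readable number.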